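Hydroxymethyl to carboxy: expected cost in compound 4

The source may report more compounds than this note shows. Statements on the series, on what has been measured and on what is new or still open speak of the compounds shown alone.

Measured so far:
Compound 1, `C/C=C/C(=O)Nc1cccc(Cn2nc(-c3ccc(Oc4ccccc4)cc3)cc2C(=O)O)c1`: in a functional assay on JeKo-1 cells (Homo sapiens) for inhibition, read by luminescence and CellTiter-Glo, with a stated time of 72 h (on this read-out higher numbers stand for weaker inhibition and lower numbers for stronger inhibition), compound 1 gives > 60000 nM, which is a limit of the assay and not a number.
Compound 2, `C/C=C/C(=O)Nc1cccc(Cn2nc(-c3ccc(Oc4ccccc4)cc3)cc2CO)c1`: in this assay compound 2 gives 22600 nM.
Compound 3, `O=C(CCl)Nc1cccc(Cn2nc(-c3ccc(Oc4ccccc4)cc3)cc2CO)c1`: in this assay compound 3 gives 400 nM.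

Compound 3 stands lowest of the two numbers measured, with the step of a 57-fold lower number from compound 2 to compound 3 (1.75 log units; beyond the scatter) resting on (chloromethyl in place of prop-1-en-1-yl on a carbonyl carbon). The other measured step, an at least 2.6-fold higher number from compound 2 to compound 1 (0.42 log units; beyond the scatter), rests on carboxy in place of hydroxymethyl on an aromatic carbon and is bounded only by the limit of > 60000 nM in this assay, at which 1 of the 3 values shown sits.

Compound 4, `O=C(CCl)Nc1cccc(Cn2nc(-c3ccc(Oc4ccccc4)cc3)cc2C(=O)O)c1`, is not yet measured. It differs from compound 3 by carboxy in place of hydroxymethyl on an aromatic carbon, the same kind of change as from compound 2 to compound 1; the description of the place is the same word for word in both cases.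

From the compounds shown here alone, the step of a 3.8-fold higher number from compound 3 to compound 4 (0.57 log units; beyond the scatter) is therefore expected to be of at least modest size, since the same change from compound 2 to compound 1 gave an at least 2.6-fold higher number from compound 2 to compound 1 (0.42 log units; beyond the scatter), and the true size of that step is unknown. Compound 4 is estimated at 1500 nM, within 500 nM to 6000 nM.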

Compound 4, half-maximal inhibitory concentration: 6300 nM
For compound 4 the middle estimate is 4.2-fold (0.62 log units) below the measured one; measured number outside the range, above it.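

In this assay, carboxy in place of hydroxymethyl on an aromatic carbon moves the number in the same direction on both cores, with a 16-fold higher number from compound 3 to compound 4 (1.20 log units; beyond the scatter) read in full and the earlier step open-ended: the same change on two cores in this assay, an at least 2.6-fold higher number (0.42 log units; beyond the scatter) from compound 2 to compound 1 and a 16-fold higher number (1.20 log units; beyond the scatter) from compound 3 to compound 4; the limit leaves it open whether they differ

Chloromethyl in place of prop-1-en-1-yl on a carbonyl carbon also keeps its direction on the carboxy core, giving an at least 9.5-fold lower number from compound 1 to compound 4 (0.97 log units; beyond the scatter): the same change on two cores in this assay, a 57-fold lower number (1.75 log units; beyond the scatter) from compound 2 to compound 3 and an at least 9.5-fold lower number (0.97 log units; beyond the scatter) from compound 1 to compound 4; the limit leaves it open whether they differ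

Compound 1 gives > 60000 nM, a limit of the assay and not a number, so the direction of the change carries across these two cores, while whether its size carries remains unsettled.

The compounds shown leave open whether a methyl ester or a primary amide in the place of the carboxy would track hydroxymethyl or carboxy in this series. From the compounds shown here alone, it is also open whether the same change would keep its direction with a third group on the carbonyl carbon, such as ethenyl.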